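Removing the Dimethylamino Group from a Hydroxamic Acid Cap

The source may report more compounds than this note shows. Statements on the series, on what has been measured and on what is new or still open speak of the compounds shown alone.

This piece concerns a small set of hydroxamic acids tested in a functional assay on G55T2 cells (Homo sapiens) for antiproliferative activity, read by WST assay, with a stated time of 72 h; a lower number here means a stronger inhibitor, a higher number a weaker inhibitor. Compound 2, with structure `Cc1ccc(NC(=O)CCN(Cc2ccc(C(=O)NO)cc2)C(=O)c2ccc(N(C)C)cc2)cc1`, gives 330 nM, the lowest of the three numbers recorded. Compound 1, with structure `CN(C)c1ccc(C(=O)N(CCC(=O)NCc2ccc(Cl)cc2)Cc2ccc(C(=O)NO)cc2)cc1`, gives 460 nM, and the step of a 1.4-fold lower number from compound 1 to compound 2 (0.14 log units; within the scatter) separates the two, so their values cannot be ranked against each other. Among the compounds with values here, compound 3, with structure `COc1cc(OC)cc(C(=O)N(CCC(=O)NCc2ccccc2)Cc2ccc(C(=O)NO)cc2)c1`, gives 14700 nM, well beyond the scatter from compound 2; it differs in more than one place, so the pair shows only that the two values lie far apart.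

Compound 4, with structure `Cc1ccc(NC(=O)CCN(Cc2ccc(C(=O)NO)cc2)C(=O)c2ccccc2)cc1`, is the next step. Compared with compound 2, the change is hydrogen in place of dimethylamino on an aromatic carbon. Within the data shown here, none of the measured steps touches this part of the molecule: the only single-point step, from compound 1 to compound 2, changes the amide substituent and says nothing about the dimethylamino group. Compound 3 carries a different group in the corresponding position, but its second change prevents reading a step from it. In this assay a modest loss is therefore expected rather than no change, with wide uncertainty.

Compound 4 is expected to give 900 nM, in a range from 300 nM to 3000 nM. The expected step is a 2.7-fold higher number from compound 2 to compound 4 (0.44 log units; beyond the scatter).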

Compound 4, half-maximal inhibitory concentration: 540 nM
The estimate for compound 4 lay 1.7-fold (0.22 log units) above the measured number, within the range that was stated.
By their numbers in this assay, from the lowest: compounds 2, 1 and 4 (each within the scatter of the next); then compound 3.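

In this assay the step is a 1.6-fold higher number from compound 2 to compound 4 (0.21 log units; within the scatter), so the two values cannot be told apart. Within the data shown here, this is the first direct reading of this position: with the 4-methylphenyl group on the amide nitrogen, a plain benzoyl gives a number that cannot be separated from that of the (4-(dimethylamino)phenyl)carbonyl, so in this pair the dimethylamino group is not needed for a value of this size. No measurement available here bears on the reason for this result.

A single pair cannot show whether the same holds with a different amide substituent, such as the 4-chlorobenzyl group of compound 1, where the dimethylamino group could matter more or less than it does here. The compounds shown also leave open how other groups on this same aromatic carbon would read, for example a fluorine atom, a carboxylic acid or a morpholine ring, any of which would show whether this position accepts a wide range of groups or only hydrogen and dimethylamino.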